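The source may report more compounds than this note shows. Statements on the series, on what has been measured and on what is new or still open speak of the compounds shown alone.

Measured in an ADME assay on a cell-free system (plasma, Rattus norvegicus) for metabolic stability, read by LC-MS, with a stated time of 60 min, tested at 100 uM; a lower number here means that less of the compound is left, a higher number that more of the compound is left:
- compound 1 `Cc1c(OCCCCOc2ccc(C(=O)O)cc2F)ccc(C(=O)CC2CCCC2)c1O`: 97%
- compound 2 `Cc1c(OCCCCOc2ccc(C(=O)O)cc2F)ccc(C(=O)CC(C)C)c1O`: 106%
- compound 3 `Cc1c(OCCCCOc2ccc(F)c(C(=O)O)c2)ccc(C(=O)C(C)C)c1O`: 83%

Compound 1 lies within the scatter of compound 2. Compound 3 lies lower than compound 1, beyond the scatter, but the two differ in more than one place, so that gap cannot be tied to a single change.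

Compound 4 `Cc1cc(C(=O)O)ccc1OCCCCOc1ccc(C(=O)CC2CCCC2)c(O)c1C` departs from compound 1 by one exchange: methyl in place of fluoro on an aromatic carbon. This puts methyl in place of fluoro on an aromatic carbon, ortho to a large group and meta to a carboxy group.

Within the data shown here, no measured step covers this exchange. Among the measured compounds shown here, the only measured step is a number 9 percentage points higher from compound 1 to compound 2 (within the scatter), which is isopropyl in place of cyclopentyl at a different place, so it bears on the exchange only indirectly. For the measured compounds named here, with that small step as the sole guide, no shift beyond the scatter is expected in this assay.

The expected step is a number 1 percentage points lower from compound 1 to compound 4 (within the scatter). For compound 4 the estimated value is 96%, with an expected range from 82% to 108%.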

Compound 4, percent of the compound remaining: 99%
Beside the measured number, compound 4's estimate is 3 percentage points below it; low and high end bracket the measured number.
By their numbers in this assay, from the lowest: compound 3; then compounds 1, 4 and 2 (each within the scatter of the next).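

In this assay, the exchange on this aromatic carbon, ortho to a large group and meta to a carboxy group, gives a number 2 percentage points higher from compound 1 to compound 4 (within the scatter), so 4-carboxy-2-methylphenyl and 4-carboxy-2-fluorophenyl cannot be told apart here. Among these compounds, this is the first readable step at this end of the molecule; the only other single-place step, a number 9 percentage points higher from compound 1 to compound 2 (within the scatter), lies on the saturated chain at the carbonyl. Nothing measured bears on why the exchange leaves the remaining compound unchanged within the scatter.

Going by these compounds, whether a chloro or a methoxy group on the same carbon would also stay within the scatter remains open. Compound 3, at 83%, differs from compound 1 in more than one place, so its gap cannot yet be assigned to any one of those differences.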